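Swapping the Aryl Group on the Ketone: Cytotoxicity Outlook

A few compounds are considered here, and "the series" means these few. Any claim that something is new, unique, unknown or untested is made for them only; others in the source may bear on it.

Compound 1 `Cc1cc(S(N)(=O)=O)ccc1NC(=O)COc1ccc2ccccc2c1C(=O)c1ccccc1` — 33800 nM
Compound 2 `Cc1ccc(C)c(C(=O)c2c(OCC(=O)Nc3ccc(S(N)(=O)=O)cc3C)ccc3ccccc23)c1` — 47500 nM
Compound 3 `Cc1cc(S(N)(=O)=O)ccc1NC(=O)COc1ccc2ccccc2c1C(=O)c1cc(Cl)cc(Br)c1` — not yet measured

In an ADME assay on C8166 cells (Homo sapiens) for cytotoxicity, read by colorimetric assay and MTT assay (on this read-out higher numbers stand for lower toxicity in this test and lower numbers for higher toxicity in this test), compound 1 gives 33800 nM, and compound 2 gives 47500 nM. Among the measured compounds shown here, the only measured step, a 1.4-fold higher number from compound 1 to compound 2 (0.15 log units; within the scatter), exchanged one aryl group on the carbonyl carbon and stayed within the scatter, so compound 2 does not stand apart from compound 1 on these numbers.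

Compound 3 is `Cc1cc(S(N)(=O)=O)ccc1NC(=O)COc1ccc2ccccc2c1C(=O)c1cc(Cl)cc(Br)c1`, and differs from compound 2 by 3-bromo-5-chlorophenyl in place of 2,5-dimethylphenyl on a carbonyl carbon. For the measured compounds named here, the single step that bears on this change is a 1.4-fold higher number from compound 1 to compound 2 (0.15 log units; within the scatter), which shows that altering the aryl group at this carbonyl carbon left this assay essentially unmoved. No halogenated aryl group has been measured here, so the expectation rests on that one step alone: in this assay no step beyond the scatter is expected for compound 3, that is a 1.2-fold lower number from compound 2 to compound 3 (0.07 log units; within the scatter). Compound 3 is therefore estimated at 40000 nM, with a range from 15000 nM to 100000 nM.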

Compound 3, half-maximal cytotoxic concentration: 36600 nM
Beside the measured number, compound 3's estimate is 1.1-fold (0.04 log units) above it; the measured number falls inside the stated range.
By their numbers in this assay, from the lowest: compounds 1, 3 and 2 (each within the scatter of the next).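

In this assay, 3-bromo-5-chlorophenyl in place of 2,5-dimethylphenyl on the carbonyl carbon gives a 1.3-fold lower number from compound 2 to compound 3 (0.11 log units; within the scatter), and the same group in place of phenyl gives a 1.1-fold higher number from compound 1 to compound 3 (0.03 log units; within the scatter), so neither step leaves the scatter. This extends the earlier finding from a dimethyl-substituted aryl group to one carrying chlorine and bromine: the three compounds cannot be told apart in this test, whichever of these three aryl groups sits on the carbonyl carbon. No measurement is available that bears on the reason for this result.

The compounds shown leave open whether a phenyl carrying an amine or a carboxylic acid, or a pyridyl or cyclohexyl group, on the carbonyl carbon would also stay within the scatter in this assay. They also leave open how a change elsewhere on the shared core would read.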